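The compounds below may be only part of what the source reports. "The series", "measured", "known", "first", "only" and "open" are said of these compounds alone.

Measured so far in a functional assay on MCF7 cells (Homo sapiens) for antiproliferative activity, read by MTT assay, with a stated time of 72 h, tested at 50 uM; a lower number here means a stronger effect, a higher number a weaker effect of the compound at the concentration tested:
compound 1 `COC(C(=O)OC(C)Cn1cnc2c1c(=O)n(C)c(=O)n2C)c1ccc(C(C)(C)C)cc1` gives 79.5%
compound 2 `CC(Cn1cnc2c1c(=O)n(C)c(=O)n2C)OC(=O)Sc1ccccc1` gives 81.9%
compound 3 `CC(Cn1cnc2c1c(=O)n(C)c(=O)n2C)OCc1cn(CCCn2nc3c(Br)c(Br)c(Br)c(Br)c3n2)nn1` gives 59.8%

Within this set compound 1 stands second highest of the three numbers. Its nearest neighbour is compound 2, whose number lies within the scatter of that of compound 1, so the two cannot be ordered. The furthest is compound 3, whose number lies beyond the scatter below that of compound 1. All three share the same core and differ only in what is attached through the oxygen on a saturated carbon.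

Compound 4 `COC(C(=O)OC(C)Cn1cnc2c1c(=O)n(C)c(=O)n2C)c1cccc2ccccc12` is not yet measured. It differs from compound 1 in one place:
naphthalen-1-yl in place of 4-(tert-butyl)phenyl on a saturated chain carbon bound to a carbonyl carbon and an oxygen on a saturated carbon
Within the data shown here, no measured pair in the set isolates such an exchange of one aromatic carbon-only group for another, so the size of the step from compound 1 to compound 4 in this assay cannot be read from a comparable measured step. Since compound 1 and compound 2, which differ in the whole group attached through that oxygen, lie within the scatter of each other, the expected step is none beyond the scatter, with the direction uncertain. Compound 4 is expected to give 75% (range 60% to 90%). This expectation corresponds to a step of a number 4.5 percentage points lower from compound 1 to compound 4 (within the scatter).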

Compound 4, a percentage reported as activity, at one concentration (the size of the read-out at that concentration, not a potency): 87.7%
Beside the measured number, compound 4's estimate is 12.7 percentage points below it; the range from low to high includes it.
By their numbers in this assay, from the lowest: compound 3; then compounds 1, 2 and 4 (each within the scatter of the next).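

In this assay, among these compounds, naphthalen-1-yl in place of 4-(tert-butyl)phenyl on a saturated chain carbon bound to a carbonyl carbon and an oxygen on a saturated carbon gives a number 8.2 percentage points higher from compound 1 to compound 4 (within the scatter), the only single-place step available so far. At this position, two six-membered aromatic rings of carbon only in place of one, with the same heavy-atom count in both groups, leave compound 1 and compound 4 unordered, so the exchange between these two aromatic groups shows no effect that can be told from the scatter. No measured property bears on this step, and nothing can be said about what lies behind it.

The compounds shown leave open whether a saturated group such as cyclohexyl, or a phenyl ring carrying an amine or a carboxylic acid, would give a step beyond the scatter at this position. Also open, as far as these compounds go, is what a hydroxyl group in place of the methoxy group on the same saturated chain carbon would do, as the read-out at this one concentration covers only these aromatic exchanges.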